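A few compounds are considered here, and "the series" means these few. Any claim that something is new, unique, unknown or untested is made for them only; others in the source may bear on it.

Compound 1 `CC(=O)N(C)CC#CCn1ccnc1` was tested in a functional assay on the whole organism for antagonist activity, with Mus musculus as the target; on this read-out lower numbers stand for an effect already at smaller amounts and higher numbers for an effect only at larger amounts of compound. In this assay compound 1 reaches only the limit of the assay, > 100 mg/kg, and not a number. Compound 2 `CC(=O)N(C)CC#CCn1cncc1C` is built from the same core with one change, (methyl in place of hydrogen on an aromatic carbon). In this assay compound 2 gives 6.6 mg/kg. That single change brought an at least 15-fold lower number from compound 1 to compound 2 (1.18 log units; beyond the scatter), a drop that stands out against the limit at which compound 1 sits, (the limit of > 100 mg/kg in this assay, at which 2 of the 3 values shown sit).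

Compound 3 `COC(=O)N(C)C(C)C#CCn1ccnc1` carries a different core; how its core differs from that of compound 1 is not broken down here. In this assay compound 3 likewise reaches only the limit, > 100 mg/kg. Compound 4 `COC(=O)N(C)C(C)C#CCn1cncc1C` is the not yet measured partner of compound 3, and the change is methyl in place of hydrogen on an aromatic carbon. This is the same kind of change as before, though the place differs in one detail: there the neighbouring ring atom bears a group of 9 heavy atoms, here a large group. Because compound 1 gave > 100 mg/kg and the change then gave an at least 15-fold lower number from compound 1 to compound 2 (1.18 log units; beyond the scatter), a comparable shift is expected, an at least 6.6-fold lower number from compound 3 to compound 4 (0.82 log units; beyond the scatter). Compound 4 is therefore estimated at 15 mg/kg, between 4 mg/kg and 60 mg/kg.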

Compound 4, dose for half-maximal effect: 3.7 mg/kg
The estimate for compound 4 lay 4.1-fold (0.61 log units) above the measured number, outside the stated range (below it).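

In this assay the methyl in place of hydrogen on an aromatic carbon brought an at least 27-fold lower number from compound 3 to compound 4 (1.43 log units; beyond the scatter) and so acted in the same direction on both cores shown, which makes two cases in this series and no more. Set side by side, the two steps read: the same change on two cores in this assay, an at least 15-fold lower number (1.18 log units; beyond the scatter) from compound 1 to compound 2 and an at least 27-fold lower number (1.43 log units; beyond the scatter) from compound 3 to compound 4; the limit leaves it open whether they differ. As far as these compounds go, what this does not show is how large the change truly is on either core, since compound 1 and compound 3 each stand only at a limit of the assay and not at a number, so the true size of each step stays unknown: the limit of > 100 mg/kg in this assay, at which 2 of the 4 values shown sit.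

The compounds shown leave open whether an ethyl group or a chlorine atom on that same aromatic carbon would do what methyl does here. They also leave open whether the step would carry over to a core with an amine at the far end of the chain.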